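Enlarging a side chain at a limited half-life

A few compounds are considered here, and "the series" means these few. Any claim that something is new, unique, unknown or untested is made for them only; others in the source may bear on it.

Compound 1 `Cc1c2c(n3c1CCN(C(=O)CN)C[C@@H](C)[C@H](C)Nc1cc-3ccc1C(N)=O)CC(C)(C)CC2=O`: > 0.5 h, a limit
Compound 2 `Cc1c2c(n3c1CCN(C(=O)C(C)(C)N)C[C@@H](C)[C@H](C)Nc1cc-3ccc1C(N)=O)CC(C)(C)CC2=O`: 0.367 h
Compound 3 `Cc1c2c(n3c1CCN(C(=O)[C@H](C)O)C[C@@H](C)[C@H](C)Nc1cc-3ccc1C(N)=O)CC(C)(C)CC2=O`: > 0.5 h, a limit

In an in vitro ADME assay on microsomes (Mus musculus) for metabolic stability (a lower number here means that the compound disappears faster, a higher number that the compound lasts longer), compound 3 gives > 0.5 h, a limit and not a number, so it stands at the limit of > 0.5 h in this assay, at which 2 of the 3 values shown sit. Compound 4 `Cc1c2c(n3c1CCN(C(=O)[C@@H](O)C(C)C)C[C@@H](C)[C@H](C)Nc1cc-3ccc1C(N)=O)CC(C)(C)CC2=O` differs from it by isopropyl in place of methyl on a saturated chain carbon bound to a carbonyl carbon and an oxygen on a saturated carbon, with isopropyl in place of methyl on a saturated chain carbon bound to a carbonyl carbon and an oxygen on a saturated carbon. The closest measured change also enlarges a group on a carbonyl carbon, and it gave an at least 1.3-fold lower number from compound 1 to compound 2 (0.13 log units; that floor lies within the scatter). The other readable step is an at least 1.3-fold higher number from compound 2 to compound 3 (0.13 log units; that floor lies within the scatter). Both are only floors, so they point weakly towards a shorter half-life. The expected change is an at least 1.2-fold lower number from compound 3 to compound 4 (0.09 log units; that floor lies within the scatter), a small drop in this assay. For compound 4 the estimated half-life is 0.4 h, with an expected range of 0.2 h to 0.8 h.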

Compound 4, half-life: 0.333 h
The estimate for compound 4 lay 1.2-fold (0.08 log units) above the measured number, and the stated range covers the measured number.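

In this assay, isopropyl in place of methyl on this saturated chain carbon gives an at least 1.5-fold lower number from compound 3 to compound 4 (0.17 log units; that floor lies within the scatter), so the larger hydroxy side chain now has a real number rather than a limit. Replacing 1-amino-1-methylethyl with 1-hydroxy-2-methylpropyl gives a 1.1-fold lower number from compound 2 to compound 4 (0.04 log units; within the scatter), and replacing aminomethyl with it gives an at least 1.5-fold lower number from compound 1 to compound 4 (0.17 log units; that floor lies within the scatter). Two of these steps are only floors, and they share one boundary: the limit of > 0.5 h in this assay, at which 2 of the 4 values shown sit.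

On these data alone, the true size of those two steps stays open. So does what an ethyl group, a longer chain or a carboxylic acid would give on this carbon.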